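Adding a methoxy group to compound 1

The source may report more compounds than this note shows. Statements on the series, on what has been measured and on what is new or still open speak of the compounds shown alone.

- compound 1 `COc1cc(/C=C2\CN(C)C/C(=C\c3ccc(Cl)cc3Cl)C2=O)cc(OC)c1`: 18800 nM
- compound 2 `COc1cc(/C=C2\CN(C)C/C(=C\c3ccc(C#N)cc3)C2=O)cc(OC)c1`: 14000 nM

Going by the values given here, in an ADME assay on L02 cells (Homo sapiens) for cytotoxicity, read by MTT assay, with a stated time of 24 h (a higher number here means a weaker inhibitor, a lower number a stronger inhibitor), compound 1 gives 18800 nM, the higher of only two numbers, yet the sole comparison is a 1.3-fold lower number from compound 1 to compound 2 (0.13 log units; within the scatter), so the pair cannot be ranked. Compound 3 `COc1cc(/C=C2\CN(C)C/C(=C\c3ccc(Cl)cc3Cl)C2=O)cc(OC)c1OC` keeps the core of compound 1 and changes one site: methoxy in place of hydrogen on an aromatic carbon. The new methoxy sits on an aromatic carbon ortho to two methoxy groups and para to a large group. Among the compounds with values here, no measured step covers this site. Within the data shown here, the one available step, a 1.3-fold lower number from compound 1 to compound 2 (0.13 log units; within the scatter), replaces a different aryl group and offers only indirect guidance. A shift beyond the scatter is therefore not expected, and no direction is favoured. The estimated step is a 1.2-fold lower number from compound 1 to compound 3 (0.07 log units; within the scatter). For compound 3 the expected value is 16000 nM, with an estimated range of 7000 nM to 35000 nM.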

Compound 3, half-maximal inhibitory concentration: 13400 nM
Estimate against measurement, compound 3: 1.2-fold (0.08 log units) above, and the stated range covers the measured number.
By their numbers in this assay, from the lowest: compounds 3, 2 and 1 (each within the scatter of the next).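

In this assay, going by these compounds alone, methoxy in place of hydrogen on an aromatic carbon gives a 1.4-fold lower number from compound 1 to compound 3 (0.15 log units; within the scatter), the first measured step at this site. With the 2,4-dichlorophenyl group of compound 1 in place, a position ortho to two methoxy groups and para to a large group thus takes the added methoxy with no shift that can be told from the scatter. No experimental evidence on the reason for this result is available here.

The compounds shown leave open how a hydroxyl group, an amine or a longer chain would read at this site. They also leave open whether the same methoxy change would stay within the scatter with the 4-cyanophenyl group of compound 2 in place of the 2,4-dichlorophenyl group.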